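Cinnamoyl oxadiazoline series: methoxy for nitro, cytotoxicity

This account rests on a few compounds, and the source may have more. Where it says the series, first, only, none or still open, it means among the compounds named here.

Compound 1, `O=C(/C=C\c1ccccc1)N1N=C(c2ccncc2)OC1c1c[nH]c2ccccc12`, gives in an ADME assay on A549 cells (Homo sapiens) for cytotoxicity, read by MTT assay, with a stated time of 48 h (on this read-out higher numbers stand for weaker inhibition of growth and lower numbers for stronger inhibition of growth), the value > 30 ug/mL, which is a limit of the assay rather than a number.
Compound 2, `O=C(/C=C\c1ccc(O)cc1)N1N=C(c2ccncc2)OC1c1c[nH]c2ccccc12`, gives in this assay the value > 30 ug/mL, also a limit.
Compound 3, `O=C(/C=C\c1ccc([N+](=O)[O-])cc1)N1N=C(c2ccncc2)OC1c1c[nH]c2ccccc12`, gives in this assay the value > 30 ug/mL, again a limit.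

Within the data shown here, compound 3 therefore stands with the two other measured compounds at the limit of > 30 ug/mL in this assay, at which 3 of the 3 values shown sit; no compound has yet given a number in this assay. The step from compound 1 to compound 2 reads a step that the two limits leave unreadable from compound 1 to compound 2, that from compound 1 to compound 3 reads a step that the two limits leave unreadable from compound 1 to compound 3, and that from compound 2 to compound 3 reads a step that the two limits leave unreadable from compound 2 to compound 3. None of them gives a readable size.

Compound 4 is `COc1ccc(/C=C\C(=O)N2N=C(c3ccncc3)OC2c2c[nH]c3ccccc23)cc1`. It differs from compound 3 by methoxy in place of nitro on an aromatic carbon, para to a large group. The three measured steps bear on this change only in that each substituent tried at that position has left the value at the limit; they give no size and no direction.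

Compound 4 is accordingly expected to give 40 ug/mL in this assay, with a range from 20 ug/mL to 100 ug/mL. The step from compound 3 to compound 4 is estimated as a step that the limit leaves unreadable from compound 3 to compound 4, most probably again ending at a limit rather than a number.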

Compound 4, concentration for 50% growth inhibition: > 30 ug/mL
Compound 4: a limit, no number; the forecaster's own chance of this, stated with the estimate: 80%; the middle value does not contradict the limit.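

Among these compounds, compound 4 gives > 30 ug/mL in this assay, again a limit, so no step from compound 1, compound 2 or compound 3 to compound 4 can be read. Whether any group at this place changes growth inhibition, and in which direction, stays open: the limit of > 30 ug/mL in this assay, at which 4 of the 4 values shown sit.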